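The source may hold more compounds than are shown below. What is called first, only, known or untested is meant among the compounds shown, and "the series" means these compounds.

Three compounds sharing a lactone core were tested in a functional assay on HL-60 cells (Homo sapiens) for cytotoxicity, read by WST assay, with a stated time of 48 h; a lower number here means that less compound is needed, a higher number that more compound is needed for the effect. Compound 1, `CCCCOc1cccc(C[C@H]2C(=O)OC[C@@H]2Cc2ccccc2)c1`, gives 26000 nM. Compound 2, `Cc1cccc(C[C@H]2C(=O)OC[C@@H]2Cc2ccccc2)c1`, gives 53000 nM. The change from compound 1 to compound 2 is methyl in place of butoxy on an aromatic carbon, and it produced a 2.0-fold higher number from compound 1 to compound 2 (0.31 log units; beyond the scatter). Compound 3, `CCCCOc1ccccc1C[C@H]1COC(=O)[C@@H]1Cc1ccc(Cl)c(Cl)c1`, gives 10000 nM; how its core differs from that of compound 1 is not broken down here, but its number is the lowest of the three.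

Compound 4, `Cc1ccccc1C[C@H]1COC(=O)[C@@H]1Cc1ccc(Cl)c(Cl)c1`, has not yet been measured in this assay. It differs from compound 3 by methyl in place of butoxy on an aromatic carbon. This is the same kind of change as that from compound 1 to compound 2, though not identical: in compound 4 the new methyl sits ortho to a large group, whereas in compound 2 it sits meta to a large group.

Within the data shown here, because the one earlier example of this change gave a 2.0-fold higher number from compound 1 to compound 2 (0.31 log units; beyond the scatter), a step of similar size is expected, namely a 2.0-fold higher number from compound 3 to compound 4 (0.30 log units; within the scatter). The estimate for compound 4 is therefore 20000 nM, likely between 8000 nM and 50000 nM.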

Compound 4, half-maximal effective concentration: 22000 nM
Compound 4: middle estimate off by 1.1-fold (0.04 log units), on the low side, and the stated range covers the measured number.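

Replacing butoxy with methyl on an aromatic carbon gave a 2.2-fold higher number from compound 3 to compound 4 (0.34 log units; beyond the scatter) in this assay, so the number went up on this second core as well. In this series, the change therefore carried over from one core to the other with much the same size and in the same direction: the same change on two cores in this assay, a 2.0-fold higher number (0.31 log units; beyond the scatter) from compound 1 to compound 2 and a 2.2-fold higher number (0.34 log units; beyond the scatter) from compound 3 to compound 4, 1.1-fold (0.03 log units) apart, within the scatter of two such steps

Among these compounds, this agreement rests on only two pairs of compounds, so it does not show that the step would keep its size on any further core, and it does not explain why the numbers go up when butoxy leaves.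

The compounds shown leave open how the number would respond to chains of intermediate length, such as ethoxy or propoxy, or to a chain longer than butoxy, such as hexyloxy. They also leave open what an amine or a carboxylic acid would do at the same place on either core.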